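This account rests on a few compounds, and the source may have more. Where it says the series, first, only, none or still open, it means among the compounds named here.

Of the compounds shown here, three have so far been measured in an assay on isolated protein (cardiac atrium) for positive allosteric modulation of histamine H2 receptor (Cavia porcellus), with a stated time of 30 min; a higher number here means that more compound is needed for the effect, a lower number that less compound is needed. Compound 1 `CC(CC(=O)/N=C(\N)NCCCc1ccccn1)c1ccccc1` gives 195 nM in this assay. Compound 2 `CC(CC(=O)/N=C(\N)NCCCc1cn[nH]c1)c1ccccc1` gives 468 nM, and compound 3 `N/C(=N\C(=O)CC(c1ccccc1)c1ccccc1)NCCCc1cn[nH]c1` gives 363 nM. Among these three numbers, that of compound 3 sits between the other two, yet its gaps to compound 2 and to compound 1 are both within the usual scatter, so no real difference between them is shown. The step of a 1.3-fold lower number from compound 2 to compound 3 (0.11 log units; within the scatter) is likewise within the scatter. For the measured compounds named here, the step of a 2.4-fold higher number from compound 1 to compound 2 (0.38 log units; beyond the scatter) is the only one that exchanges one ring for another at that same place on the chain, and it is modest in size.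

Compound 4 `N/C(=N\C(=O)CC(c1ccccc1)c1ccccc1)NCCCc1ncn[nH]1` differs from compound 3 by 1H-1,2,4-triazol-5-yl in place of 1H-pyrazol-4-yl on a saturated chain carbon, three bonds along the chain from an amine nitrogen. Going by the values given here, no measured step replaces this ring with the entering one, so the earlier ring exchange is the only guide, and it moved the number only modestly. For compound 4 the expected step is a 1.2-fold higher number from compound 3 to compound 4 (0.09 log units; within the scatter), most likely nothing beyond the scatter. Compound 4 is therefore estimated at 450 nM, with a range from 180 nM to 1100 nM.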

Compound 4, half-maximal effective concentration: 204 nM
For compound 4 the middle estimate is 2.2-fold (0.34 log units) above the measured one; the measured number falls inside the stated range.
By their numbers in this assay, from the lowest: compounds 1, 4, 3 and 2 (each within the scatter of the next, the first and the last beyond it).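

Placing 1H-1,2,4-triazol-5-yl in place of 1H-pyrazol-4-yl on a saturated chain carbon, three bonds along the chain from an amine nitrogen, gives a 1.8-fold lower number from compound 3 to compound 4 (0.25 log units; within the scatter) in this assay. For the compounds shown here, this is the first exchange here between two five-membered aromatic rings, and it shows that a ring with 3 hetero atoms and 2 hydrogen-bond acceptors, rather than 2 hetero atoms and 1 acceptor, brings no difference beyond the scatter. No measurement is available to explain this result.

The compounds shown leave open whether the same ring exchange would read alike with methyl in place of phenyl on the other side of the molecule. They also leave open how a 1H-imidazol-4-yl ring or a longer chain would fare at this place.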